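From pyridin-2-yl to 4-chlorophenyl in an antiproliferative series

The source may hold more compounds than are shown below. What is called first, only, known or untested is meant among the compounds shown, and "the series" means these compounds.

Within the data shown here, in a functional assay on HT-29 cells (Homo sapiens) for antiproliferative activity, read by MTT assay, with a stated time of 24 h (on this read-out lower numbers stand for stronger inhibition and higher numbers for weaker inhibition), compound 2 (`COc1ccc(C(=O)/C=C/c2ccccn2)c2c1C=CC(C)(C)O2`) gives 2120 nM as the only true number so far. Compound 1 (`COc1ccc(C(=O)/C=C/c2ccc(-c3ccccc3)cc2)c2c1C=CC(C)(C)O2`) shows > 10000 nM as a limit of the assay and not a number. Compound 3 (`COc1ccc(C(=O)/C=C/c2ccc(Cl)cc2)c2c1C=CC(C)(C)O2`) carries 4-chlorophenyl in place of pyridin-2-yl on a double-bonded chain carbon bound to a double-bonded chain carbon. Among the measured compounds shown here, no measured step covers this change, so the expected step is a 1.7-fold higher number from compound 2 to compound 3 (0.22 log units; within the scatter) as a small weakening in this assay that stays near the scatter. Compound 3 is expected at 3500 nM within an estimated range of 1200 nM to 10000 nM on this read-out.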

Compound 3, half-maximal inhibitory concentration: > 10000 nM
Compound 3 ended at the assay's limit (the forecaster's own chance of this, stated with the estimate: 20%); middle value at least 2.8-fold (0.45 log units) from the limit.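

In this assay, 4-chlorophenyl in place of pyridin-2-yl gives an at least 4.7-fold higher number from compound 2 to compound 3 (0.67 log units; beyond the scatter), so at this double-bonded chain carbon, pyridin-2-yl is the only group shown that gives a true number. Compound 3 sits at a limit and not a number, so the full size of this step stays unknown because the reading stops there: the limit of > 10000 nM in this assay, at which 2 of the 3 values shown sit.
The step between compound 1 and compound 3 cannot be read.

The change swaps the ring nitrogen for carbon and adds chlorine at once, and the compounds shown cannot separate the two. Plain phenyl or 4-aminophenyl at this place remains an open case.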